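Heptyl to hexyl: a one-carbon step in the series

The source may report more compounds than this note shows. Statements on the series, on what has been measured and on what is new or still open speak of the compounds shown alone.

Compound 1 `COc1nc2ccc(Br)cc2cc1C(c1ccccc1)n1cc(-c2ccc(Br)cc2)nn1` gives 7.43% in an ADME assay on PC-3 cells (Homo sapiens) for cytotoxicity, read by sulforhodamine B assay, with a stated time of 48 h, tested at 10 uM; a higher number here means more inhibition at the concentration tested (going by the name of the read-out), a lower number less inhibition. Compound 2 `CCCCCCCc1cn(C(c2ccccc2)c2cc3cc(Br)ccc3nc2OC)nn1` gives 4.42% in this assay, reached by a step of a number 3 percentage points lower from compound 1 to compound 2 (within the scatter). On these two numbers compound 2 cannot be separated from compound 1; the two readings lie within the scatter of each other, so no order between them can be claimed.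

Compound 3 `CCCCCCc1cn(C(c2ccccc2)c2cc3cc(Br)ccc3nc2OC)nn1` is the next member, differing from compound 2 by hydrogen in place of methyl on a saturated chain carbon, six bonds along the chain from an aromatic carbon. Within the data shown here, the only measured step, heptyl in place of 4-bromophenyl on an aromatic carbon, is a far larger change at the same chain and still moved the reading by a number 3 percentage points lower from compound 1 to compound 2 (within the scatter), within the scatter. Among the measured compounds shown here, a one-carbon shortening of that chain has no measured precedent here. A step of a number 0.6 percentage points higher from compound 2 to compound 3 (within the scatter) is therefore expected, none beyond the scatter. Compound 3 is estimated at 5%, in the range -5% to 15%.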

Compound 3, a percentage reported as inhibition, at one concentration (the size of the read-out at that concentration, not a potency): 2.32%
Estimate against measurement, compound 3: 2.7 percentage points above; the range from low to high includes it.
By their numbers in this assay, from the lowest: compounds 3, 2 and 1 (each within the scatter of the next).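

In this assay, among these compounds, the heptyl to hexyl difference gives a number 2.1 percentage points lower from compound 2 to compound 3 (within the scatter) and is the first measured difference on the saturated chain itself; at this place, one carbon more or less cannot be told apart from the scatter. Hexyl in place of 4-bromophenyl on the aromatic carbon gives a number 5.1 percentage points lower from compound 1 to compound 3 (within the scatter) and so also stays within the scatter, as heptyl did, which means neither alkyl chain can be separated from the aryl group on these readings. No supporting data bear on this result.

Still open, as far as these compounds go, is whether an amine or a carboxylic acid at the chain end, or a much longer chain, would give a reading beyond the scatter. These readings come from one concentration, so the potency of the series stays undefined.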